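From cyano to nitro on compound 3

A few compounds are considered here, and "the series" means these few. Any claim that something is new, unique, unknown or untested is made for them only; others in the source may bear on it.

In a functional assay on VCaP cells (Homo sapiens) for antiproliferative activity, read by propidium iodide staining, with a stated time of 96 h (a higher number here means a weaker inhibitor, a lower number a stronger inhibitor), compound 1 (`CC(O)(CSc1ccc(OC(F)(F)F)cc1)C(=O)Nc1ccc(S(F)(F)(F)(F)F)cc1`) gives 16000 nM and compound 2 (`CC(O)(CSc1ccc(F)cc1)C(=O)Nc1cccc(S(F)(F)(F)(F)F)c1`) gives 21900 nM while compound 3 (`CC(O)(COc1cccc(S(F)(F)(F)(F)F)c1)C(=O)Nc1ccc(C#N)cc1C(F)(F)F`) gives 10300 nM on the same scale. That places compound 3 within the usual scatter of compound 1, and beyond the scatter on the stronger side of compound 2. The next molecule, compound 4 (`CC(O)(COc1cccc(S(F)(F)(F)(F)F)c1)C(=O)Nc1ccc([N+](=O)[O-])cc1C(F)(F)F`), carries nitro in place of cyano on an aromatic carbon. For the measured compounds named here, no measured pair differs in one place only, so nothing here sizes this swap directly, and the estimated 1.0-fold lower number from compound 3 to compound 4 (0.01 log units; within the scatter) is expected to stay within the scatter. The estimated value for compound 4 is 10000 nM with an expected range from 4500 nM to 22000 nM in this measurement.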

Compound 4, half-maximal inhibitory concentration: 20300 nM
Compound 4: the middle estimate sits 2.0-fold (0.31 log units) below what was measured, and the stated range covers the measured number.
By their numbers in this assay, from the lowest: compounds 3, 1, 4 and 2 (each within the scatter of the next, the first and the last beyond it).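

For the compounds shown here, compound 3 and compound 4 form the first pair here that differs in one place only, so the swap at this aromatic carbon, para to a large group, can now be sized directly. In this assay the change to nitro gives a 2.0-fold higher number from compound 3 to compound 4 (0.29 log units; within the scatter), so this measurement does not separate nitro from cyano at this position. Nothing available here offers an explanation for the step.

On these data alone, it remains open how a carboxylic acid or an amine at this position would read in this assay. Whether the swap would give a similar step on a different core is also unknown.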